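Chloro to trifluoromethyl on the phenyl ring of the amino group

The source may report more compounds than this note shows. Statements on the series, on what has been measured and on what is new or still open speak of the compounds shown alone.

Three compounds of the series have numbers in a functional assay on RXF 393 cells (Homo sapiens) for inhibition, read by sulforhodamine B assay, with a stated time of 48 h; a lower number here means a stronger inhibitor of growth, a higher number a weaker inhibitor of growth. Compound 1 `COc1cc(-c2nn(-c3cccc(NC(=O)c4cccc(C(F)(F)F)c4)c3)cc2-c2ccncc2)ccc1Cl` gives 811 nM. Compound 2 `COc1cc(-c2nn(-c3cccc(NC(=O)Nc4ccc(Cl)c(Cl)c4)c3)cc2-c2ccncc2)ccc1Cl` gives 859 nM, and compound 3 `O=C(Nc1cccc(-n2cc(-c3ccncc3)c(-c3ccc(Cl)c(O)c3)n2)c1)Nc1ccc(Cl)c(Cl)c1` gives 1000 nM. Compound 2 therefore holds the second highest of the three numbers, with compound 1 nearest and compound 3 furthest, both within the scatter. The two single-point steps show how flat the set is: a 1.1-fold higher number from compound 1 to compound 2 (0.02 log units; within the scatter) and a 1.2-fold higher number from compound 2 to compound 3 (0.07 log units; within the scatter) both remain within the scatter.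

Compound 4 `COc1cc(-c2nn(-c3cccc(NC(=O)Nc4ccc(Cl)c(C(F)(F)F)c4)c3)cc2-c2ccncc2)ccc1Cl` is not yet measured. It differs from compound 2 in one place: trifluoromethyl in place of chloro on an aromatic carbon. For the measured compounds named here, of the measured steps, only the step from compound 1 to compound 2 involves the same ring, and it exchanged the whole group rather than a single substituent; it stayed within the scatter, as did the step from compound 2 to compound 3 elsewhere in the molecule. Going by the values given here, no measured step reports a chloro to trifluoromethyl exchange on this ring. On that basis no step beyond the scatter is expected in this assay in either direction, which is written as a 1.0-fold lower number from compound 2 to compound 4 (0.00 log units; within the scatter). Compound 4 is accordingly estimated at 850 nM, with a range from 400 nM to 1800 nM.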

Compound 4, concentration for 50% growth inhibition: 1180 nM
For compound 4 the middle estimate is 1.4-fold (0.14 log units) below the measured one; the measured number falls inside the stated range.
By their numbers in this assay, from the lowest: compounds 1, 2, 3 and 4 (each within the scatter of the next).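

In this assay, for the compounds shown here, the step of a 1.4-fold higher number from compound 2 to compound 4 (0.14 log units; within the scatter) is the first reading of a single-substituent exchange on this ring: trifluoromethyl for chloro, ortho to a chloro group and meta to a large group. Going from 1 heavy atom to 4 heavy atoms at this position therefore leaves the number within the scatter, and the wider exchange on the carbonyl carbon, a 1.5-fold higher number from compound 1 to compound 4 (0.16 log units; within the scatter), does the same, so neither the single substituent nor the whole group separates these compounds. No measurement shown bears on why this position reads so flat.

Still open is whether the position stays as flat with an amine, a carboxylic acid or a longer chain there, since the compounds shown carry only chloro or trifluoromethyl at this place on the urea-linked ring. Also open, on these data alone, is whether the exchange of chloro for trifluoromethyl reads the same on the hydroxy compound 3, or in any read-out other than this assay.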